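Taking the hydroxy group off compound 2

The source may report more compounds than this note shows. Statements on the series, on what has been measured and on what is new or still open speak of the compounds shown alone.

In a functional assay on RAW264.7 cells (Mus musculus) for inhibition, read by Griess assay, with a stated time of 24 h (on this read-out higher numbers stand for weaker inhibition and lower numbers for stronger inhibition), compound 1 `O=C(S[C@@]12CC[C@H](O)[C@@H]1C(=O)NC2=O)c1ccccc1Cl` gives 127000 nM and compound 2 `O=C(S[C@]12CC[C@H](O)[C@H]1C(=O)NC2=O)c1ccccc1Cl` gives 178000 nM. For the measured compounds named here, compound 2 thus stands level with compound 1, the only other compound measured, since the two numbers lie within the scatter of each other. Going by the values given here, the single measured step, a 1.4-fold higher number from compound 1 to compound 2 (0.15 log units; within the scatter), goes with the fact that compounds 1 and 2 differ only in the configuration as drawn, and both compounds keep their hydroxy.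

Compound 3 `O=C(S[C@]12CCC[C@H]1C(=O)NC2=O)c1ccccc1Cl` departs from compound 2 by hydrogen in place of hydroxy on a saturated ring carbon, which is hydrogen in place of hydroxy on a saturated ring carbon. Among the compounds with values here, no measured step makes this change, so the step between compound 1 and compound 2 bears on it only loosely: it shows what a change of drawn configuration does, not what losing the hydroxy does. With so little to go on, no step beyond the scatter is expected in this assay, and no firm direction can be argued. The expected change is a 1.5-fold lower number from compound 2 to compound 3 (0.17 log units; within the scatter). For compound 3 the estimated value is 120000 nM. The expected range for compound 3 runs from 50000 nM to 300000 nM.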

Compound 3, half-maximal inhibitory concentration: 59800 nM
Beside the measured number, compound 3's estimate is 2.0-fold (0.30 log units) above it; the measured number falls inside the stated range.
By their numbers in this assay, from the lowest: compound 3; then compounds 1 and 2 (each within the scatter of the next).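

In this assay, for the compounds shown here, hydrogen in place of hydroxy on this saturated ring carbon gives a 3.0-fold lower number from compound 2 to compound 3 (0.47 log units; beyond the scatter), the first step in the set that lies beyond the scatter, though a modest one. This position on the five-membered ring therefore responds to the change, and losing the hydroxy goes with stronger inhibition rather than weaker, so the hydroxy is not required for the activity seen in this read-out. The earlier step, a 1.4-fold higher number from compound 1 to compound 2 (0.15 log units; within the scatter), lay within the scatter and could not speak to this, since both of its compounds keep their hydroxy and the step concerns drawn configuration alone: the fact that compounds 1 and 2 differ only in the configuration as drawn.

As far as these compounds go, whether the step reflects the loss of the hydroxy as such or the presence of hydrogen stays open, and a methoxy group, a fluorine atom or an amine on the same ring carbon would help to separate the two readings. Also open, from the compounds shown here alone, is whether the same change made on compound 1, with its different drawn configuration, would give a step of like direction and size.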